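The source may hold more compounds than are shown below. What is called first, only, known or untested is meant among the compounds shown, and "the series" means these compounds.

Working notes on the series.

The shared core of compound 1 `CC(C)(C)Cc1csc(N)c1C(=O)c1ccc(Cl)cc1` is carried unchanged through compound 2 `CC(C)(C)Cc1c(-c2ccoc2)sc(N)c1C(=O)c1ccc(Cl)cc1` and compound 3 `CC(C)(C)Cc1c(-c2ccncc2)sc(N)c1C(=O)c1ccc(Cl)cc1`; only the substituent on one aromatic carbon of the five-membered ring changes. In an assay on CHO cells for displacement of a labelled ligand from adenosine receptor A1 (Homo sapiens), read by scintillation counting, tested at 10 uM (on this read-out higher numbers stand for more inhibition at the one concentration tested (going by the name of the read-out) and lower numbers for less inhibition), compound 1 gives 1%. In this assay compound 2 gives 1%. In this assay compound 3 gives 1%. All three values sit level with one another: no change at the digits printed from compound 1 to compound 2 (within the scatter), no change at the digits printed from compound 1 to compound 3 (within the scatter) and no change at the digits printed from compound 2 to compound 3 (within the scatter). Compound 3 therefore stands level with compounds 1 and 2 at the digits shown, and nothing in the series so far has moved the read-out in this assay out of the scatter.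

Compound 4 `CC(C)(C)Cc1c(-c2cccnc2)sc(N)c1C(=O)c1ccc(Cl)cc1` is the next member. It differs from compound 3 by pyridin-3-yl in place of pyridin-4-yl on an aromatic carbon.

Among the compounds with values here, the steps that bear on this change are those in which a six-membered aromatic ring with one hetero atom was introduced or exchanged on the same aromatic carbon: no change at the digits printed from compound 1 to compound 3 (within the scatter) and no change at the digits printed from compound 2 to compound 3 (within the scatter). Both were flat. Since exchanging one such ring for another, and adding one in place of hydrogen, left the read-out unchanged, the step of no change at the digits printed from compound 3 to compound 4 (within the scatter) is expected to lie within the scatter as well. Compound 4 is expected to give about 1%, with a range from 0% to 10%.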

Compound 4, a percentage reported as inhibition, at one concentration (the size of the read-out at that concentration, not a potency): 1%
For compound 4 middle estimate and measured number coincide at the digits printed; the measured number falls inside the stated range.
By their numbers in this assay, from the lowest: compounds 1, 2, 3 and 4 (each within the scatter of the next).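

In this assay, within the data shown here, the exchange of pyridin-4-yl for pyridin-3-yl on the aromatic carbon next to the ring sulfur gives no change at the digits printed from compound 3 to compound 4 (within the scatter); this is the first change that keeps the same atoms and only joins them differently, and it leaves the read-out flat. The two longer steps read alike, with no change at the digits printed from compound 2 to compound 4 (within the scatter) for pyridin-3-yl in place of furan-3-yl and no change at the digits printed from compound 1 to compound 4 (within the scatter) for pyridin-3-yl in place of hydrogen, so hydrogen and the three aromatic rings shown all stand level on this carbon. No measured information is available on why this position stays flat in this read-out.

Still open, as far as these compounds go, is whether any other kind of group on this carbon, such as an aminomethyl group, a carboxylic acid or a longer chain such as n-hexyl, would move the read-out in this assay. Also open, from the compounds shown here alone, is what changes elsewhere would do, since the neopentyl group, the amino group and the group of 9 heavy atoms stay fixed in all four compounds, so the flatness speaks for this one carbon only.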